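From Hydroxy to ((2-aminoethyl)carbonyl)oxy on Compound 2

The compounds below may be only part of what the source reports. "The series", "measured", "known", "first", "only" and "open" are said of these compounds alone.

Of the compounds shown here, three have been tested in an ADME assay for solubility (on this read-out higher numbers stand for higher solubility and lower numbers for lower solubility), so far, and none of them has returned an exact number. Compound 1 `Cc1c(O)c(=O)ccn1CCCc1cc(C(C)(C)C)c(O)c(C(C)(C)C)c1` gives < 100 ug/mL as a limit and not a number. Compound 2 `Cc1c(C)c2c(c(C)c1O)CC(CCn1ccc(=O)c(O)c1C)O2` gives < 100 ug/mL as a limit too, and it is the starting point of this story. Compound 3 `Cc1c(C)c2c(c(C)c1O)CCC(C)(CNCCCCn1ccc(=O)c(O)c1C)O2` gives < 100 ug/mL as a limit as well. All that is available, then, is the limit of < 100 ug/mL in this assay, at which 3 of the 3 values shown sit, and compound 2 cannot be ranked against the other two.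

Compound 4 `Cc1c(C)c2c(c(C)c1OC(=O)CCN)CC(CCn1ccc(=O)c(O)c1C)O2` has not yet been measured. It carries (2-aminoethyl)carbonyl in place of hydrogen on an oxygen on an aromatic ring, counted as (2-aminoethyl)carbonyl in place of hydrogen on an oxygen on an aromatic ring and the rest of the two structures is the same. Within the data shown here, no pair of measured compounds shows what a single change does in this assay so what follows is a judgement and not a reading from a trend. The expected move is upward and beyond the usual scatter of repeat measurements, with an estimated size of an at least 8.0-fold higher number from compound 2 to compound 4 (0.90 log units; beyond the scatter) on this scale. The estimate for compound 4 is 800 ug/mL with an expected range from 100 ug/mL to 5000 ug/mL when it is tested.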

Compound 4, solubility: 10000 ug/mL
Compound 4: middle estimate off by 13-fold (1.10 log units), on the low side, and the stated range ends below it.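

Among these compounds, until now, this assay had returned only limits and no change could be read; here, for the first time, a single swap has a visible result, with (2-aminoethyl)carbonyl replacing hydrogen on an oxygen on an aromatic ring giving an at least 100-fold higher number from compound 2 to compound 4 (2.00 log units; beyond the scatter) on this scale. So this one position on the shared core, left unchanged in every other respect, is enough to carry the series far beyond the scatter of repeat measurements. Compound 2 gives < 100 ug/mL as a limit and not a number, so the step is a minimum and the true gap may be wider, since the starting point of the step is only bounded: the limit of < 100 ug/mL in this assay, at which 3 of the 4 values shown sit.

The compounds shown cannot separate the part played by the terminal amine from that of the carbonyl attached to the oxygen; an acetyl group, a longer chain ending in an amine or a chain ending in a carboxylic acid at the same oxygen would begin to do that. Compound 1 and compound 3 also carry a hydroxy on an aromatic ring, and whether the same change would have a similar result on those different structures remains an open question.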